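A Double Bond Drawn the Other Way

A few compounds are considered here, and "the series" means these few. Any claim that something is new, unique, unknown or untested is made for them only; others in the source may bear on it.

- Compound 1 `COc1c([N+](=O)[O-])cc(/C=C\c2ccc3ccccc3c2)cc1[N+](=O)[O-]`: > 5000 nM (a limit)
- Compound 2 `CN(C)c1c([N+](=O)[O-])cc(/C=C/c2ccc3ccccc3c2)cc1[N+](=O)[O-]`: > 5000 nM (a limit)

Both compounds were tested in a functional assay on HeLa cells (Homo sapiens) for inhibition; on this read-out lower numbers stand for stronger inhibition and higher numbers for weaker inhibition. Compound 1 reads > 5000 nM, which is a limit of the assay and not a number. Compound 2 reads > 5000 nM in this assay, and this too is a limit and not a number. The whole picture so far is the limit of > 5000 nM in this assay, at which 2 of the 2 values shown sit. For the measured compounds named here, no measured step is available to give the size of a change.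

The next compound, compound 3 `CN(C)c1c([N+](=O)[O-])cc(/C=C\c2ccc3ccccc3c2)cc1[N+](=O)[O-]`, differs from compound 2 in geometry alone: the two compounds have the same atoms and bonds and differ only in configuration as drawn: 1 of 1 stereo elements differ; a double bond is drawn E in compound 2 and Z in compound 3. With only the limit of > 5000 nM in this assay, at which 2 of the 2 values shown sit, as a guide, no shift beyond the scatter is expected in either direction. The expected change is a step that the limit leaves unreadable from compound 2 to compound 3. The estimate for compound 3 is 6000 nM, with an expected range from 1500 nM to 20000 nM, and another limit is quite likely.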

Compound 3, half-maximal inhibitory concentration: > 5000 nM
Compound 3: no number, only a limit (the forecaster's own chance of this, stated with the estimate: 70%); the middle value lies beyond the limit too.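

In this assay compound 3 gives > 5000 nM, which is a limit and not a number. The steps from compound 2 and from compound 1 to compound 3 cannot be read. The compounds shown leave open whether double bond geometry, or dimethylamino in place of methoxy, changes inhibition at all.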